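The source may report more compounds than this note shows. Statements on the series, on what has been measured and on what is new or still open speak of the compounds shown alone.

Measured so far:
compound 1 `O=C(Nc1ccncc1)Nc1ccccc1C(F)(F)F` — 100 mg/kg
compound 2 `N#Cc1ccccc1NC(=O)Nc1ccncc1` — > 300 mg/kg

In a functional assay on the whole organism with Mus musculus as the target, in the maximal electroshock model, with a stated time of 30 min (on this read-out higher numbers stand for an effect only at larger amounts of compound and lower numbers for an effect already at smaller amounts), compound 1 gives 100 mg/kg. Compound 2 gives only a limit of this assay, > 300 mg/kg, standing at the limit of > 300 mg/kg in this assay, at which 1 of the 2 values shown sits, and at the higher of the two numbers shown. For the measured compounds named here, the single measured step, an at least 3.0-fold higher number from compound 1 to compound 2 (0.47 log units; beyond the scatter), runs into that limit. Compound 3 `CC(C)c1ccccc1NC(=O)Nc1ccncc1` differs from compound 2 by isopropyl in place of cyano on an aromatic carbon. No measured step involves an isopropyl, so the one step shown bears only loosely on this change: it marks the cyano compound as the one at the limit. Compound 3 is therefore expected to give 100 mg/kg, within a range from 30 mg/kg to 300 mg/kg. The expected step is an at least 3.0-fold lower number from compound 2 to compound 3 (0.47 log units; beyond the scatter).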

Compound 3, minimum effective dose: 100 mg/kg
For compound 3 middle estimate and measured number coincide at the digits printed, and the stated range covers the measured number.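

In this assay, isopropyl in place of cyano on this aromatic carbon gives an at least 3.0-fold lower number from compound 2 to compound 3 (0.47 log units; beyond the scatter), so the cyano compound is not representative of every group at this position. Isopropyl in place of trifluoromethyl gives no change at the digits printed from compound 1 to compound 3 (within the scatter), so two groups with different atoms read alike here. Compound 2 remains a limit, not a number: the limit of > 300 mg/kg in this assay, at which 1 of the 3 values shown sits.

On these data alone, the full size of the step from the cyano compound stays open. Also open, as far as these compounds go, is how a methoxy group, an amine or a carboxylic acid on this carbon would read.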